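The source may report more compounds than this note shows. Statements on the series, on what has been measured and on what is new or still open speak of the compounds shown alone.

Working notes on the series. Two compounds carry a measurement in a functional assay on 1321-N1 cells for agonist activity at Free fatty acid receptor 1 (Homo sapiens), read by calcium flux, with a stated time of 0.4 s; on this read-out lower numbers stand for an effect already at smaller amounts and higher numbers for an effect only at larger amounts of compound. Compound 1 `C/C=C\C#Cc1ccc(CCC(=O)O)c(F)c1` gives 47.9 nM in this assay. Compound 2 `O=C(O)CCc1ccc(C#CC2CC2)cc1` differs from compound 1 in several places at once. In this assay compound 2 gives 5010 nM. Compound 1 therefore holds the lower of the two numbers, and the gap up to compound 2 lies beyond the usual scatter. Going by the values given here, since no pair of measured compounds differs in a single place, the set yields no step whose size can be read directly.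

Compound 3 `C/C(C#Cc1ccc(CCC(=O)O)c(F)c1)=C/CO` is not yet measured. Relative to compound 1 the change is 3-hydroxy-1-methylprop-1-en-1-yl in place of prop-1-en-1-yl on a triple-bonded carbon. The acid chain, the fluorine and the triple bond of compound 1 are kept; nothing measured in the set speaks to a hydroxyl or an added methyl on that tail, so the expectation rests on the kept parts alone. The step from compound 1 to compound 3 is expected to be small and toward a higher number, about a 2.1-fold higher number from compound 1 to compound 3 (0.32 log units; beyond the scatter), at the edge of the scatter. Compound 3 is estimated at 100 nM, with a range from 25 nM to 400 nM.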

Compound 3, half-maximal effective concentration: 427 nM
Compound 3: middle estimate off by 4.3-fold (0.63 log units), on the low side; measured number above the stated range.
By their numbers in this assay, from the lowest: compound 1; then compound 3; then compound 2.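

In this assay, going by these compounds alone, the substituent on the triple-bonded carbon proves able to move the read-out: 3-hydroxy-1-methylprop-1-en-1-yl in place of prop-1-en-1-yl gives an 8.9-fold higher number from compound 1 to compound 3 (0.95 log units; beyond the scatter), the first step that can be read at a single place. The change is beyond the scatter and toward a higher number, so this larger, hydroxyl-bearing group does not match the prop-1-en-1-yl of compound 1 in this assay, even with the acid chain, the fluorine and the triple bond kept. No supporting measurement is available to explain the size or direction of this step.

The compounds shown leave open whether the step belongs to the added methyl, the hydroxyl or the two together, as neither appears on this tail without the other. Also open, on these data alone, is whether an amine or a methoxy group in place of the hydroxyl, or a longer chain on the triple-bonded carbon, would bring the number back toward that of compound 1 or raise it further.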